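The source may report more compounds than this note shows. Statements on the series, on what has been measured and on what is new or still open speak of the compounds shown alone.

Measured so far in a functional assay on MCF7 cells (Homo sapiens) for antiproliferative activity, read by sulforhodamine B assay, with a stated time of 48 h; a lower number here means a stronger inhibitor of growth, a higher number a weaker inhibitor of growth:
- compound 1 `COc1ccc(-c2cc(N3CCC(CCNS(N)(=O)=O)CC3)ncn2)cc1`: 56600 nM
- compound 2 `NS(=O)(=O)NCCC1CCN(c2cc(-c3ccc(Cl)cc3)ncn2)CC1`: 19700 nM
- compound 3 `COc1ccccc1-c1cc(N2CCC(CCNS(N)(=O)=O)CC2)ncn1`: 69800 nM

Compound 2 differs from compound 1 by chloro in place of methoxy on an aromatic carbon; this gave a 2.9-fold lower number from compound 1 to compound 2 (0.46 log units; beyond the scatter). Compound 3 differs from compound 1 by 2-methoxyphenyl in place of 4-methoxyphenyl on an aromatic carbon, and the two give a 1.2-fold higher number from compound 1 to compound 3 (0.09 log units; within the scatter). From compound 2 to compound 3 the step is a 3.5-fold higher number from compound 2 to compound 3 (0.55 log units; beyond the scatter).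

Compound 4 `NS(=O)(=O)NCCC1CCN(c2cc(-c3ccccc3Cl)ncn2)CC1` is not yet measured. It differs from compound 3 by chloro in place of methoxy on an aromatic carbon. This is the same kind of change as that from compound 1 to compound 2, but the place is not the same: there the chloro sits para to a large group, here ortho to a large group. Within the data shown here, only one measured example of the change exists, so the expected step for compound 4 is taken as a 2.8-fold lower number from compound 3 to compound 4 (0.45 log units; beyond the scatter), resting on the step of compound 1 to compound 2, a 2.9-fold lower number from compound 1 to compound 2 (0.46 log units; beyond the scatter), applied to compound 3 at 69800 nM. Given the different place, the range is kept wide. Compound 4 is thus estimated at 25000 nM in this assay, expected between 9000 nM and 70000 nM.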

Compound 4, concentration for 50% growth inhibition: 44800 nM
Compound 4: the middle estimate sits 1.8-fold (0.25 log units) below what was measured; low and high end bracket the measured number.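

The two steps of chloro in place of methoxy cannot be told apart in this assay: the same change on two cores in this assay, a 2.9-fold lower number (0.46 log units; beyond the scatter) from compound 1 to compound 2 and a 1.6-fold lower number (0.19 log units; within the scatter) from compound 3 to compound 4, 1.8-fold (0.27 log units) apart, within the scatter of two such steps

The change can therefore be carried from the core of compound 1 to the core of compound 3 without a measurable difference between the two steps, but this rests on two pairs only, and a 1.6-fold lower number from compound 3 to compound 4 (0.19 log units; within the scatter) does not by itself establish a gain on the second core. With chloro kept, the place on the aromatic ring does register, with a 2.3-fold higher number from compound 2 to compound 4 (0.36 log units; beyond the scatter), whereas a 1.3-fold lower number from compound 1 to compound 4 (0.10 log units; within the scatter) leaves 2-chlorophenyl and 4-methoxyphenyl unresolved, so agreement between the two steps does not show that the change is independent of place.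

The compounds shown leave open whether fluoro, methyl or a nitrile on the same aromatic carbons would follow chloro. They also leave open whether a longer chain on the shared core would alter these steps.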